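A few compounds are considered here, and "the series" means these few. Any claim that something is new, unique, unknown or untested is made for them only; others in the source may bear on it.

In a functional assay on H4 cells for agonist activity at growth hormone secretagogue receptor type 1 (Homo sapiens), read by FLIPR (a lower number here means that less compound is needed, a higher number that more compound is needed for the effect), compound 1 `CC(C)(N)C(=O)N[C@H](COCc1ccccc1)c1nnnn1Cc1ccc(NS(C)(=O)=O)cc1` gives 259 nM, and compound 2 `COC(=O)CCCn1nnnc1[C@@H](COCc1ccccc1)NC(=O)C(C)(C)N` gives 55 nM, the lowest of the two numbers; the step of a 4.7-fold lower number from compound 1 to compound 2 (0.67 log units; beyond the scatter) lies beyond the scatter. Compound 3 `CCCCNC(=O)CCCn1nnnc1[C@@H](COCc1ccccc1)NC(=O)C(C)(C)N` differs from compound 2 by butylamino in place of methoxy on a carbonyl carbon. Among the measured compounds shown here, the single measured step alters the chain on the aromatic nitrogen, not the carbonyl substituent, so no measured step bears on this change and the direction is open. Compound 3 is therefore expected to stay close, with the step of a 1.1-fold higher number from compound 2 to compound 3 (0.04 log units; within the scatter) not beyond the scatter. Compound 3 is estimated at 60 nM, within 20 nM to 180 nM.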

Compound 3, half-maximal effective concentration: 30 nM
For compound 3 the middle estimate is 2.0-fold (0.30 log units) above the measured one; measured number inside the range.
By their numbers in this assay, from the lowest: compounds 3 and 2 (each within the scatter of the next); then compound 1.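

In this assay the carbonyl carbon takes butylamino as well as methoxy, with a 1.8-fold lower number from compound 2 to compound 3 (0.26 log units; within the scatter), so the added heavy atoms and the hydrogen-bond donor leave the two values indistinguishable. The change in the chain on the aromatic nitrogen also holds with the amide, as 2-(butylcarbamoyl)ethyl in place of 4-(methanesulfonamido)phenyl gives an 8.6-fold lower number from compound 1 to compound 3 (0.94 log units; beyond the scatter) and so remains clear of compound 1.

Whether a carboxylic acid or a chain longer than butylamino on this carbonyl carbon stays in the same range is open. Nothing available explains why methoxy and butylamino read alike here.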